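The source may hold more compounds than are shown below. What is called first, only, known or untested is meant among the compounds shown, and "the series" means these compounds.

Of the compounds shown here, two with a shared core have been measured so far. In a functional assay on SR cells (Homo sapiens) for inhibition, read by sulforhodamine B assay, with a stated time of 48 h (on this read-out higher numbers stand for weaker inhibition of growth and lower numbers for stronger inhibition of growth), compound 1 `CCCCOc1ccc(NC(=O)n2nc(N)c3ccccc32)cc1` gives 16000 nM. For the measured compounds named here, the only other measured compound, compound 2 `Nc1nn(C(=O)Nc2c(F)cccc2F)c2ccccc12`, gives 12900 nM in this assay, a number that lies within the usual scatter of the one for compound 1, so the two cannot be told apart. Compound 1 therefore stands at a point where no ordering among the measured numbers can be read.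

The step of interest leads from compound 1 to compound 3 `Nc1nn(C(=O)Nc2ccc(Cc3ccccc3)cc2)c2ccccc12`. The change is benzyl in place of butoxy on an aromatic carbon. Going by the values given here, nothing measured so far shows what a change at this place does, and the two measured compounds differ from each other at more than one place, so no comparable step is available.

Given that lack, the step is expected to be small, with no clear direction beyond the scatter, and the estimate for compound 3 in this assay is 12000 nM, within a range from 4000 nM to 40000 nM. This estimate means a step of a 1.3-fold lower number from compound 1 to compound 3 (0.12 log units; within the scatter) is expected.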

Compound 3, concentration for 50% growth inhibition: 15.3 nM
Compound 3: the middle estimate sits 780-fold (2.89 log units) above what was measured; the whole stated range lies above it.
By their numbers in this assay, from the lowest: compound 3; then compounds 2 and 1 (each within the scatter of the next).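

In this assay, for the compounds shown here, benzyl in place of butoxy on an aromatic carbon, para to a large group, gives a 1000-fold lower number from compound 1 to compound 3 (3.02 log units; beyond the scatter) and so shows that this place on the ring can have a very large effect on the growth-inhibition read-out, something the earlier compounds could not reveal. The change swaps a ring-free group of four carbons and one oxygen, with one hydrogen-bond acceptor, for a group of seven carbons with a six-membered aromatic ring and no hydrogen-bond acceptor, while neither group carries a net charge or a hydrogen-bond donor. Nothing available gives a measured reason for the size of this step, so the result stands as an observation and not as an explanation.

A single exchange changes the ring, the oxygen and the number of heavy atoms together, so the compounds shown do not reveal which of these differences matters. Phenoxy, which keeps the aromatic ring and restores an oxygen, or a plain hexyl chain, which has no ring or oxygen, at the same carbon would help to pull these differences apart.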